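A few compounds are considered here, and "the series" means these few. Any claim that something is new, unique, unknown or untested is made for them only; others in the source may bear on it.

Measured compounds:
compound 1 `CCOC(=O)CSc1nncc2cnc(C)n12`
compound 2 `C=CCn1ncc2cnc(COC)n2c1=O`
compound 3 `C=CCSc1nncc2cnc(C)n12`

In a functional assay for inhibition, with Homo sapiens as the target (on this read-out higher numbers stand for weaker inhibition and lower numbers for stronger inhibition), compound 1 gives 52000 nM. In this assay compound 3 gives 61000 nM. For compound 2 this assay reports only a limit and no number, > 48000 nM; (the limit of > 48000 nM in this assay, at which 1 of the 3 values shown sits). Compound 1 and compound 3 differ in one place, (ethoxycarbonyl in place of vinyl on a saturated chain carbon bound to a sulfur), and that change made a 1.2-fold lower number from compound 3 to compound 1 (0.07 log units; within the scatter). How the core of compound 2 differs from the core of compound 3 is not broken down here.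

Compound 4 `CCOC(=O)Cn1ncc2cnc(COC)n2c1=O` has not been measured. It stands to compound 2 as compound 1 stands to compound 3: ethoxycarbonyl in place of vinyl on a saturated chain carbon bound to an aromatic nitrogen. The place is not the same word for word, a saturated chain carbon bound to an aromatic nitrogen here against one bound to a sulfur there, so this counts as the same kind of change, not the same change.

For compound 4 the expected step is a step that the limit leaves unreadable from compound 2 to compound 4, which rests on the measured step being within the scatter, a 1.2-fold lower number from compound 3 to compound 1 (0.07 log units; within the scatter). Compound 4 is expected in this assay at 60000 nM, with a range from 25000 nM to 200000 nM. As compound 2 sits at a limit, a limit rather than a number is the likelier report for compound 4.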

Compound 4, half-maximal inhibitory concentration: > 48000 nM
Compound 4: no number, only a limit (the forecaster's own chance of this, stated with the estimate: 65%); the middle value is on the limit's open side.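

Compound 2 and compound 4 each report only a limit in this assay, so no step can be read between them: the limit of > 48000 nM in this assay, at which 2 of the 4 values shown sit. The compounds shown leave open whether ethoxycarbonyl in place of vinyl on a saturated chain carbon bound to an aromatic nitrogen changes inhibition on the core of compound 2.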